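From methoxy to chloro in compound 1

The source may hold more compounds than are shown below. What is called first, only, known or untested is meant among the compounds shown, and "the series" means these compounds.

In a functional assay on KB 3-1 cells (Homo sapiens) for cytotoxicity, read by MTT assay, with a stated time of 68 h (a higher number here means a weaker inhibitor, a lower number a stronger inhibitor), compound 1 (`COc1cccc(-c2cccc(NC(=O)C(Cl)Cl)c2)c1`) gives 43300 nM as its reading. Within the data shown here, compound 3 (`O=C(Nc1cccc(-c2ccc(F)cc2)c1)C(Cl)Cl`) gives 26200 nM as its reading, and these two numbers lie within the usual scatter of each other, so compound 1 does not stand apart from the only other number available. Compound 2 (`COc1cccc(-c2cc(NC(=O)C(Cl)Cl)cc(-c3cccc(OC)c3)c2)c1`) is known only as a limit (> 30000 nM) and not as a number.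

The step followed here leads to compound 4 (`O=C(Nc1cccc(-c2cccc(Cl)c2)c1)C(Cl)Cl`), which has chloro in place of methoxy on an aromatic carbon, meta to a large group (chloro in place of methoxy on an aromatic carbon). Among the measured compounds shown here, the only measured step in this small set (a step that the limit leaves unreadable from compound 1 to compound 2) has no readable size and concerns a different change, so it offers no guide to this swap. For the measured compounds named here, with compound 3 at 26200 nM as the only other number, no step beyond the scatter is expected in this assay in either direction.

For compound 4 the estimate is 30000 nM as the middle, with 13000 nM and 70000 nM as the expected ends of its range. This expected shift (a 1.4-fold lower number from compound 1 to compound 4 (0.16 log units; within the scatter)) stays within the scatter.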

Compound 4, half-maximal inhibitory concentration: > 50000 nM
Compound 4: a limit, no number (the forecaster's own chance of this, stated with the estimate: 20%); middle value at least 1.6-fold (0.22 log units) away from the limit.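

In this assay, chloro in place of methoxy on this aromatic carbon gives an at least 1.1-fold higher number from compound 1 to compound 4 (0.06 log units; that floor lies within the scatter) and so offers only a floor for the step, not its size. The reading of compound 4 is a limit and not a number: the limit of > 50000 nM in this assay, at which 1 of the 4 values shown sits. Among these compounds, what the earlier compounds could not show is that this change at this place, where methoxy with 2 heavy atoms and 1 hydrogen-bond acceptor leaves and chloro with 1 heavy atom and 0 hydrogen-bond acceptors enters, brings no lower number into view.

The compounds shown leave open how large the step from methoxy to chloro really is, since a floor within the scatter cannot separate a real loss from no change at all. They also leave open whether a different group on the same aromatic carbon, such as a hydroxy group, an amine or a carboxylic acid, would give a number that stands clear of the scatter from the reading of compound 1, and in which direction.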